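A few compounds are considered here, and "the series" means these few. Any claim that something is new, unique, unknown or untested is made for them only; others in the source may bear on it.

Measured compounds:
- Compound 1, `COc1ncnc2c1c(-c1ccoc1)cn2[C@@H]1O[C@H](CO)[C@@H](O)[C@H]1O`, gives 290 nM in a functional assay on HepG2 cells (Homo sapiens) for antiproliferative activity, read by XTT assay, with a stated time of 72 h; a lower number here means a stronger inhibitor, a higher number a weaker inhibitor.
- Compound 2, `COc1ncnc2c1c(-c1cc3ccccc3o1)cn2[C@@H]1O[C@H](CO)[C@@H](O)[C@H]1O`, gives > 20000 nM in this assay, which is a limit of the assay and not a number.
- Compound 3, `Nc1nc(N)c2c(-c3ccoc3)cn([C@@H]3O[C@H](CO)[C@@H](O)[C@H]3O)c2n1`, gives > 20000 nM in this assay, again a limit of the assay and not a number.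

The first two compounds share a core and differ in one place: 1-benzofuran-2-yl in place of furan-3-yl on an aromatic carbon. This change made the step of an at least 68-fold higher number from compound 1 to compound 2 (1.83 log units; beyond the scatter), and because of the limit of > 20000 nM in this assay, at which 2 of the 3 values shown sit, the true size of that step may be even larger than the number suggests. Compound 3 carries a different core; the difference between the two cores is not broken down here.

Compound 4, `Nc1nc(N)c2c(-c3cc4ccccc4o3)cn([C@@H]3O[C@H](CO)[C@@H](O)[C@H]3O)c2n1`, has not yet been measured. It stands to compound 3 as compound 2 stands to compound 1: 1-benzofuran-2-yl in place of furan-3-yl on an aromatic carbon. The place of the change is the same in words for both pairs, so this is the same change on a second core. Compound 3 already sits at a limit of the assay. With the same change having pushed compound 1 to a limit, the expectation is that compound 4 stays at or beyond that limit, a step of roughly a step that the limit leaves unreadable from compound 3 to compound 4, with the true number uncertain. The expected value for compound 4 is therefore 40000 nM, between 20000 nM and 200000 nM.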

Compound 4, half-maximal inhibitory concentration: > 20000 nM
Compound 4: no number, only a limit (the forecaster's own chance of this, stated with the estimate: 95%); the middle value is on the limit's open side.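

Compound 4 gives > 20000 nM in this assay, which is a limit of the assay and not a number, and compound 3 sits at that same limit, so no step between compound 3 and compound 4 can be read: the limit of > 20000 nM in this assay, at which 3 of the 4 values shown sit.

The compounds shown leave open whether 1-benzofuran-2-yl in place of furan-3-yl changes activity at all on the core of compound 3, as it does on the core of compound 1.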